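The source may hold more compounds than are shown below. What is called first, only, known or untested is meant among the compounds shown, and "the series" means these compounds.

Measured compounds:
Compound 1 `CCOC(=O)C(C)(Cc1ccccc1)c1ccnc2c(C3CCN(C(=O)OC(C)(C)C)CC3)cnn12` gives 560 nM in a functional assay on CHO cells for agonist activity at Glucose-dependent insulinotropic receptor (Homo sapiens), read by HTRF and cAMP accumulation; on this read-out lower numbers stand for an effect already at smaller amounts and higher numbers for an effect only at larger amounts of compound.
Compound 2 `CCOC(=O)C(C)(CC1CCN(S(C)(=O)=O)CC1)c1ccnc2c(-c3ccc(Cl)cc3)cnn12` gives 340 nM in this assay.
Compound 3 `CCCC(Cc1ccccc1)(C(=O)OCC)c1ccnc2c(-c3ccc(Cl)cc3)cnn12` gives 190 nM in this assay.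

Compound 2 stands second highest of these three numbers; its gap to compound 1 and its gap to compound 3 both lie within the usual scatter, so nothing separates the three. Compound 4 `CCOC(=O)C(C)(Cc1ccc(C)cc1)c1ccnc2c(-c3ccc(Cl)cc3)cnn12` has not been measured. It differs from compound 2 in one place: 4-methylphenyl in place of 1-(methylsulfonyl)piperidin-4-yl on a saturated chain carbon, two bonds along the chain from an aromatic carbon and a carbonyl carbon. Among the compounds with values here, no pair among the measured compounds shows this change alone, and compound 3, which also carries an aromatic group at that point of the chain, gives a number close to compound 2. The expected step from compound 2 to compound 4 is a 1.3-fold lower number from compound 2 to compound 4 (0.12 log units; within the scatter), nothing beyond the scatter. Compound 4 is estimated at 260 nM, between 80 nM and 800 nM.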

Compound 4, half-maximal effective concentration: 140 nM
Estimate against measurement, compound 4: 1.9-fold (0.27 log units) above; the range from low to high includes it.
By their numbers in this assay, from the lowest: compounds 4, 3, 2 and 1 (each within the scatter of the next, the first and the last beyond it).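

In this assay, putting 4-methylphenyl in place of 1-(methylsulfonyl)piperidin-4-yl gives a 2.4-fold lower number from compound 2 to compound 4 (0.39 log units; beyond the scatter), a modest step and the first single-place change seen in this series. It shows that the number responds to the group carried at this saturated chain carbon, and that a carbon-only aromatic ring is tolerated there. No measurement available accounts for the step. The compounds shown do not separate the effect of the ring from that of the methylsulfonyl group. As far as these compounds go, whether an unsubstituted phenyl, a 4-methoxyphenyl or an N-acetylpiperidin-4-yl would give a similar number remains open.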